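The source may hold more compounds than are shown below. What is called first, only, known or untested is meant among the compounds shown, and "the series" means these compounds.

Among the compounds with values here, compound 2 `O=C(/C=C/c1ccc(Cl)cc1)Nc1ccc2c(c1)OCCO2` gives 320 nM in a functional assay on CHO cells for inhibition of transient receptor potential cation channel subfamily V member 1 (Homo sapiens) (a lower number here means a stronger inhibitor, a higher number a weaker inhibitor), the only plain number among the two values shown. Compound 1 `O=C(/C=C/c1ccc(-c2ccccc2)cc1)Nc1ccc2c(c1)OCCO2` is reported in this assay only as a limit, > 4000 nM. Within the data shown here, the single measured step is an at least 12-fold lower number from compound 1 to compound 2 (1.09 log units; beyond the scatter), and the limit of > 4000 nM in this assay, at which 1 of the 2 values shown sits, bounds how large that step may truly be. Compound 3 `O=C(/C=C/c1ccc(O)cc1)Nc1ccc2c(c1)OCCO2` differs from compound 2 by hydroxy in place of chloro on an aromatic carbon. This exchange is not of the same kind as the measured step, which therefore gives no firm direction for it. Compound 3 is expected to weaken moderately, a 2.8-fold higher number from compound 2 to compound 3 (0.45 log units; beyond the scatter). Compound 3 is estimated at 900 nM, within 250 nM to 3500 nM.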

Compound 3, half-maximal inhibitory concentration: > 4000 nM
Compound 3: no number, only a limit; the forecaster's own chance of this, stated with the estimate: 20%; middle value at least 4.4-fold (0.64 log units) away from the limit.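

Going from 4-chlorophenyl to 4-hydroxyphenyl gives an at least 12-fold higher number from compound 2 to compound 3 (1.09 log units; beyond the scatter) in this assay. This exchange replaces one heavy atom with one heavy atom and adds a hydrogen-bond donor and acceptor, so a large loss at this position now appears without the added ring that compound 1 carries. Compound 1 and compound 3 are both reported as limits, and the step between them cannot be read: the limit of > 4000 nM in this assay, at which 2 of the 3 values shown sit.

The compounds shown leave open how a fluoro, a methoxy or an amino group would read at this position. They also leave open whether any group here gives a lower number than chloro.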